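The source may hold more compounds than are shown below. What is called first, only, known or untested is meant among the compounds shown, and "the series" means these compounds.

Compound 1 `COc1cc(/C=C/C(=O)c2sc(Nc3ccccc3C)nc2C)cc(OC)c1OC` was tested in a functional assay on PC-3 cells (Homo sapiens) for cytotoxicity, read by MTT assay; a lower number here means a stronger inhibitor, a higher number a weaker inhibitor. In this assay compound 1 gives only a limit, > 25000 nM. Compound 2 `COc1cccc(/C=C/C(=O)c2sc(Nc3cccc(Cl)c3)nc2C)c1` likewise returns only a limit in this assay, > 25000 nM. Among the compounds with values here, both measured values sit at the limit of > 25000 nM in this assay, at which 2 of the 2 values shown sit, so no step between measured compounds can be sized here. Compound 3 `COc1cc(/C=C/C(=O)c2sc(Nc3cccc(C)c3)nc2C)cc(OC)c1OC` differs from compound 1 by 3-methylphenyl in place of 2-methylphenyl on a nitrogen on an aromatic ring. With both neighbours at the limit, the step from compound 1 to compound 3 is expected to stay near zero, a step that the limit leaves unreadable from compound 1 to compound 3, and compound 3 is estimated at 30000 nM, between 10000 nM and 100000 nM, most likely again only a limit.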

Compound 3, half-maximal inhibitory concentration: > 25000 nM
Compound 3 ended at the assay's limit (the forecaster's own chance of this, stated with the estimate: 80%); the middle value lies beyond the limit too.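

No step can be read from compound 1 to compound 3, as both return only a limit in this assay and the compared values are all limits: the limit of > 25000 nM in this assay, at which 3 of the 3 values shown sit.

The compounds shown leave open which change to the shared core, if any, would give a measurable value in this assay.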